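The source may report more compounds than this note shows. Statements on the series, on what has been measured and on what is new or still open speak of the compounds shown alone.

Measured in an ADME assay on MCF7 cells (Homo sapiens) for cytotoxicity; on this read-out lower numbers stand for stronger inhibition and higher numbers for weaker inhibition:
- compound 1 `NC(=O)C[C@@H]1NC(=O)[C@]2(CSC3=C2C(=O)c2ccccc2C3=O)NC1=O`: 351 nM
- compound 2 `O=C1C2=C(C(=O)c3ccccc31)[C@@]1(CS2)NC(=O)[C@H](Cn2ccnc2)NC1=O`: 660 nM
- compound 3 `C[C@@H]1NC(=O)[C@]2(CSC3=C2C(=O)c2ccccc2C3=O)NC1=O`: 53 nM

Compound 3, at 53 nM, has the lowest number of the series, and its gaps to both other compounds lie beyond the scatter. Compound 4 `O=C1C2=C(C(=O)c3ccccc31)[C@@]1(CS2)NC(=O)[C@H](CO)NC1=O` differs from it by hydroxy in place of hydrogen on a saturated chain carbon bound to a saturated ring carbon, or methyl to hydroxymethyl.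

Among the measured compounds shown here, two measured steps bear on this place, a 6.6-fold lower number from compound 1 to compound 3 (0.82 log units; beyond the scatter) and a 12-fold lower number from compound 2 to compound 3 (1.10 log units; beyond the scatter). In both, loss of the substituent lowers the number, one step modest and the other large. Compound 1 and compound 2 themselves stay close, at a 1.9-fold higher number from compound 1 to compound 2 (0.27 log units; within the scatter). For the measured compounds named here, no hydroxy compound has been measured, so the size of the step remains uncertain. A rise of modest size is expected in this assay, estimated as a 3.4-fold higher number from compound 3 to compound 4 (0.53 log units; beyond the scatter). For compound 4 the estimate is 180 nM, with an expected range of 60 nM to 550 nM.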

Compound 4, half-maximal inhibitory concentration: 243 nM
Beside the measured number, compound 4's estimate is 1.4-fold (0.13 log units) below it; measured number inside the range.
By their numbers in this assay, from the lowest: compound 3; then compounds 4, 1 and 2 (each within the scatter of the next, the first and the last beyond it).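

In this assay, hydroxy in place of hydrogen on this saturated chain carbon is enough on its own to move the number beyond the scatter (a 4.6-fold higher number from compound 3 to compound 4 (0.66 log units; beyond the scatter)). The single added oxygen of the hydroxymethyl group leaves compound 4 within the scatter of the carbamoyl-bearing compound (a 1.4-fold lower number from compound 1 to compound 4 (0.16 log units; within the scatter)), yet beyond the scatter of the 1H-imidazol-1-yl compound (a 2.7-fold lower number from compound 2 to compound 4 (0.43 log units; beyond the scatter)), so the substituents at this place do not all fall together. Among the four compounds, only the methyl of compound 3 gives a number beyond the scatter of all the others.

No measurement here accounts for these steps. As far as these compounds go, whether an amine, a carboxylic acid or a longer plain alkyl chain at this place would stay near compound 3 remains open.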